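The compounds below may be only part of what the source reports. "The series", "measured", "known", "first", "only" and "open" are said of these compounds alone.

Compound 1 `Cn1nc2c(=O)n(CC3(O)CCN(Cc4ccc(-c5ccco5)cc4Cl)CC3)cnc2c1-c1ccc(CNC=O)cc1`: 3480 nM
Compound 2 `CNCc1ccc(-c2c3ncn(CC4(O)CCN(Cc5ccc(-c6ccco6)cc5Cl)CC4)c(=O)c3nn2C)cc1`: 637 nM

In an ADME assay on the whole organism (Rattus norvegicus, strain Sprague-Dawley) for pharmacokinetics, read by LC-MS, with a stated time of 24 h, at a dose of 2 mg/kg by the intravenous route (a higher number here means more compound in the circulation at the dose given, a lower number less compound in the circulation), compound 2 has the lower of the two numbers. Compound 3 `Cn1nc2c(=O)n(CC3(O)CCN(Cc4ccc(-c5ccco5)cc4Cl)CC3)cnc2c1-c1ccc(CN)cc1` differs from it in one place: hydrogen in place of methyl on an amine nitrogen. For the measured compounds named here, the one measured step at this nitrogen was a 5.5-fold lower number from compound 1 to compound 2 (0.74 log units; beyond the scatter), but that step put methyl in place of formyl. Going by the values given here, no measured pair shows hydrogen in place of methyl, so this evidence is thin. Only a small change, none beyond the scatter, is expected, and the estimated step is a 1.1-fold higher number from compound 2 to compound 3 (0.04 log units; within the scatter). Compound 3 is estimated at 700 nM, with an expected range of 280 nM to 1750 nM.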

Compound 3, maximal plasma concentration: 1290 nM
Beside the measured number, compound 3's estimate is 1.8-fold (0.27 log units) below it; low and high end bracket the measured number.
By their numbers in this assay, from the lowest: compound 2; then compound 3; then compound 1.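

In this assay this amine nitrogen responds even to a single methyl: there is a 2.0-fold higher number from compound 2 to compound 3 (0.31 log units; beyond the scatter) on losing it, and there is a 2.7-fold lower number from compound 1 to compound 3 (0.43 log units; beyond the scatter) when hydrogen replaces formyl. The plain amino compound therefore lies between the formyl and methyl forms, an order that one step alone could not show. Nothing measured here explains this order.

From the compounds shown here alone, whether an ethyl or acetyl group on this nitrogen would fit that order stays open, as does whether the order would hold on a changed core.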